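Swapping the Chain Amine of Compound 1

The source may hold more compounds than are shown below. What is called first, only, known or untested is meant among the compounds shown, and "the series" means these compounds.

Compound 1 `CN(C)CCCCCn1c2c(c3ccccc31)C(=O)c1c[n+]([O-])c3ccccc3c1C2=O` is the reference point of this series. In a functional assay on MCF7 cells (Homo sapiens) for cytotoxicity, read by MTT assay, with a stated time of 72 h (a higher number here means a weaker inhibitor, a lower number a stronger inhibitor), compound 1 gives 200 nM, the lowest of the two numbers shown, though its nearest neighbour sits within the scatter. Compound 3 `O=C1c2c[n+]([O-])c3ccccc3c2C(=O)c2c1c1ccccc1n2CCN1CCCC1` gives 320 nM in this assay, and the step of a 1.6-fold higher number from compound 1 to compound 3 (0.20 log units; within the scatter) stays within the scatter. Compound 2 `O=C1c2c[n+]([O-])c3ccccc3c2C(=O)c2c1c1ccccc1n2Cc1cn(C[C@H](O)CO)nn1` reaches only a limit of this assay, giving > 1000 nM, which is a limit rather than a number (the limit of > 1000 nM in this assay, at which 1 of the 3 values shown sits). The steps of an at least 5.0-fold higher number from compound 1 to compound 2 (0.69 log units; beyond the scatter) and an at least 3.1-fold lower number from compound 2 to compound 3 (0.49 log units; beyond the scatter) both go beyond the scatter.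

Compound 4 `CN1CCN(CCCCCn2c3c(c4ccccc42)C(=O)c2c[n+]([O-])c4ccccc4c2C3=O)CC1` differs from compound 1 by 4-methylpiperazin-1-yl in place of dimethylamino on a saturated chain carbon, five bonds along the chain from an aromatic nitrogen. The step that bears most on this change is a 1.6-fold higher number from compound 1 to compound 3 (0.20 log units; within the scatter), where one basic amine replaced another and nothing beyond the scatter followed. The step of an at least 5.0-fold higher number from compound 1 to compound 2 (0.69 log units; beyond the scatter), where the amine gave way to a triazole bearing a diol, is the only one beyond the scatter. Since compound 4 keeps a basic amine on its chain, no step beyond the scatter is expected in this assay. Compound 4 is therefore expected to give 250 nM, within 120 nM to 600 nM. The expected step is a 1.3-fold higher number from compound 1 to compound 4 (0.10 log units; within the scatter).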

Compound 4, half-maximal inhibitory concentration: 1260 nM
Compound 4: middle estimate off by 5.0-fold (0.70 log units), on the low side; measured number outside the range, above it.
By their numbers in this assay, from the lowest: compounds 1 and 3 (each within the scatter of the next); then compound 4.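

In this assay, within the data shown here, the steps from compound 1 had so far gone beyond the scatter only where the amine gave way to a triazole bearing a diol, but compound 4 keeps an amine on its chain and still goes beyond it (a 6.3-fold higher number from compound 1 to compound 4 (0.80 log units; beyond the scatter)). The exchange of dimethylamino for 4-methylpiperazin-1-yl, five bonds along the chain from an aromatic nitrogen, therefore does not leave the number in place, and compound 4 also stands apart from the pyrrolidin-1-yl compound (a 3.9-fold higher number from compound 3 to compound 4 (0.60 log units; beyond the scatter)). The step from compound 2 to compound 4 cannot be read, because compound 2 stands at a limit: the limit of > 1000 nM in this assay, at which 1 of the 4 values shown sits.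

Open, from the compounds shown here alone, is whether the size of the ring or its second nitrogen goes with this rise. A piperidin-1-yl or morpholin-4-yl group on the same chain would separate the two.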